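Fluoro-methyl aryl swap in the fused-core amide series

A few compounds are considered here, and "the series" means these few. Any claim that something is new, unique, unknown or untested is made for them only; others in the source may bear on it.

Compound 2 `Cc1cnc(C(=O)NC2CC2)cc1-c1cc2cnnc(-c3ccccc3Cl)c2n(C)c1=O` gives 1.65 L/kg in an in vivo ADME assay on the whole organism (strain Sprague-Dawley) for pharmacokinetics, with Rattus norvegicus as the target, at a dose of 2 mg/kg by the intravenous route; on this read-out higher numbers stand for wider distribution into tissues and lower numbers for narrower distribution; compound 1 `Cc1cnc(C(=O)NC2CC2)cc1-c1cc2cnnc(-c3ccccc3C)c2n(C)c1=O` gives 2.09 L/kg in this assay, and the two sit within the usual scatter, as the step of a 1.3-fold lower number from compound 1 to compound 2 (0.10 log units; within the scatter) shows. Going by the values given here, compound 3 `Cc1cnc(C(=O)NC2CC2)cc1-c1cc2cnnc(-c3ccc(F)cc3C)c2n(C)c1=O` carries the change (4-fluoro-2-methylphenyl in place of 2-chlorophenyl on an aromatic carbon); the only step that bears on it is the methyl-to-chloro exchange, which moved little. A step toward compound 1, and no more than that, is therefore expected, so for compound 3 the estimate in this assay is 2 L/kg (range 1.2 L/kg to 3.4 L/kg), an expected step of a 1.2-fold higher number from compound 2 to compound 3 (0.08 log units; within the scatter).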

Compound 3, volume of distribution at steady state: 1.73 L/kg
Beside the measured number, compound 3's estimate is 1.2-fold (0.06 log units) above it; the range from low to high includes it.
By their numbers in this assay, from the lowest: compounds 2, 3 and 1 (each within the scatter of the next).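

In this assay, adding fluoro to the aryl group gives a 1.2-fold lower number from compound 1 to compound 3 (0.08 log units; within the scatter), and the full aryl exchange gives a 1.0-fold higher number from compound 2 to compound 3 (0.02 log units; within the scatter). Neither step leaves the scatter, so this position now holds three aryl groups that the read-out does not separate, including one with two substituents. No supporting measurement bears on this result.

Still open, on these data alone, is whether an amine or a carboxylic acid on this aryl group would give a step beyond the scatter. As far as these compounds go, a saturated ring in place of the aryl group is equally open.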